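Swapping the end of a short chain on a brominated diaryl ether

The source may hold more compounds than are shown below. What is called first, only, known or untested is meant among the compounds shown, and "the series" means these compounds.

Compound 2 `C=CCOc1c(Br)cc(Br)cc1Oc1ccc(Br)cc1Br` was tested in a functional assay on HL-60 cells (Homo sapiens) for cytotoxicity, read by MTT assay, with a stated time of 24 h (a higher number here means a weaker inhibitor, a lower number a stronger inhibitor), and gave 27.9 ug/mL. Among the three numbers in hand it sits at one end, but the gaps to its neighbours are small: compound 1 `OCCOc1c(Br)cc(Br)cc1Oc1ccc(Br)cc1Br` gives 28.2 ug/mL, and the step of a 1.0-fold lower number from compound 1 to compound 2 (0.00 log units; within the scatter); compound 3 `CCOC(=O)C(C)Oc1c(Br)cc(Br)cc1Oc1ccc(Br)cc1Br` gives 35.7 ug/mL, and the step of a 1.3-fold higher number from compound 2 to compound 3 (0.11 log units; within the scatter). The step of a 1.3-fold higher number from compound 1 to compound 3 (0.10 log units; within the scatter) completes the picture, so the three measured compounds cannot be told apart on these numbers.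

Compound 4 `BrCCOc1c(Br)cc(Br)cc1Oc1ccc(Br)cc1Br` shares the core of compound 2 and differs from it in one place: bromomethyl in place of vinyl on a saturated chain carbon bound to an oxygen on an aromatic ring. The most relevant earlier step is the one at the same place, where a vinyl replaced a hydroxymethyl on the saturated chain carbon bound to the ring oxygen, and that step a 1.0-fold lower number from compound 1 to compound 2 (0.00 log units; within the scatter) left the number essentially unchanged. The larger exchange to a 1-(ethoxycarbonyl)ethyl also stayed within the scatter, as a 1.3-fold higher number from compound 2 to compound 3 (0.11 log units; within the scatter) shows. Within the data shown here, nothing measured so far suggests that what hangs on this chain matters much here, so the expected step of a 1.0-fold higher number from compound 2 to compound 4 (0.00 log units; within the scatter) is none beyond the scatter. Compound 4 is therefore estimated at 28 ug/mL in this assay, with a likely range from 18 ug/mL to 45 ug/mL.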

Compound 4, half-maximal inhibitory concentration: 26.2 ug/mL
Compound 4: the middle estimate sits 1.1-fold (0.03 log units) above what was measured, and the stated range covers the measured number.
By their numbers in this assay, from the lowest: compounds 4, 2, 1 and 3 (each within the scatter of the next).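

In this assay the chain end now carries a bromine, which none of the earlier chains had there, and bromomethyl in place of vinyl gives a 1.1-fold lower number from compound 2 to compound 4 (0.03 log units; within the scatter) on the same footing as bromo in place of hydroxy, which gives a 1.1-fold lower number from compound 1 to compound 4 (0.03 log units; within the scatter) for the same chain length. Set against the bulkier 1-(ethoxycarbonyl)ethyl, the 2-bromoethyl gives a 1.4-fold lower number from compound 3 to compound 4 (0.13 log units; within the scatter) and so also stays within the scatter, which means that a hydroxy, a double bond, an ester and now a bromine at this place all leave the four compounds indistinguishable. Nothing measured here goes beyond these cell numbers, so no data bear on why the chain end makes so little difference.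

Still open, from the compounds shown here alone, is whether any group at this place can move the number at all, for instance an amine or a carboxylic acid at the chain end, or a much longer chain. All four compounds also share the same core with its bromines, so the compounds shown cannot say what the core itself contributes to the number.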